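The source may report more compounds than this note shows. Statements on the series, on what has been measured and on what is new or still open speak of the compounds shown alone.

The measured compounds:
compound 1 `Cc1cc(=O)oc2cc(OCC(O)CN3CCC(C(N)=O)CC3)ccc12`: > 100000 nM
compound 2 `Cc1c(Cc2cccc(F)c2)c(=O)oc2cc(OCC(O)CN3CCC(C(N)=O)CC3)ccc12`: 53300 nM
compound 3 `Cc1c(Cc2ccc(Br)cc2)c(=O)oc2cc(OCC(O)CN3CCC(C(N)=O)CC3)ccc12`: > 100000 nM

In an ADME assay on A549 cells (Homo sapiens) for cytotoxicity, read by CellTiter-Glo (a lower number here means that less compound is tolerated, a higher number that more compound is tolerated), compound 1 gives > 100000 nM, which is a limit of the assay. Compound 2 gives 53300 nM. Compound 3 gives > 100000 nM, again a limit of the assay, so compound 3 stands at the limit of > 100000 nM in this assay, at which 2 of the 3 values shown sit, where the number is not resolved. The measured steps are an at least 1.8-fold lower number from compound 1 to compound 2 (0.27 log units; that floor lies within the scatter), a step that the two limits leave unreadable from compound 1 to compound 3 and an at least 1.8-fold higher number from compound 2 to compound 3 (0.27 log units; that floor lies within the scatter); none of them is readable beyond the scatter.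

Compound 4 `Cc1c(Cc2ccc(F)cc2F)c(=O)oc2cc(OCC(O)CN3CCC(C(N)=O)CC3)ccc12` differs from compound 3 by 2,4-difluorophenyl in place of 4-bromophenyl on a saturated chain carbon bound to an aromatic carbon. For the measured compounds named here, the one step that bears on it is the swap of one halogenated benzyl for another, an at least 1.8-fold higher number from compound 2 to compound 3 (0.27 log units; that floor lies within the scatter), whose floor lies within the scatter. Hence no step beyond the scatter is expected in this assay. Compound 4 is expected to give about 100000 nM, with a range from 40000 nM to 250000 nM. The expected step of a number no higher from compound 3 to compound 4 (the limit leaves the size open) is thus estimated to be small, with a fair chance that only a limit is reported again.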

Compound 4, half-maximal cytotoxic concentration: > 100000 nM
Compound 4 ended at the assay's limit; the forecaster's own chance of this, stated with the estimate: 55%; the middle value lies on the limit itself.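

In this assay compound 4 gives > 100000 nM, a limit of the assay, so 2,4-difluorobenzyl now joins 4-bromobenzyl and hydrogen at that limit: the limit of > 100000 nM in this assay, at which 3 of the 4 values shown sit. Placing 2,4-difluorophenyl where 3-fluorophenyl stood gives an at least 1.8-fold higher number from compound 2 to compound 4 (0.27 log units; that floor lies within the scatter), so this change, with two fluorines on the ring, opens no gap that can be read beyond the scatter. For the compounds shown here, the steps that join two limits cannot be read, so the position shows a tolerance for a second halogen pattern but no order among the compounds at the limit.

From the compounds shown here alone, only hydrogen and halogenated benzyl groups stand at this position, so it remains open whether a benzyl carrying an amine or a carboxylic acid would give a resolved number in this assay. A longer chain in place of the benzyl carbon is equally untested among these compounds.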